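Swapping the dichlorobenzyl for a hydroxymethylbenzyl group

A few compounds are considered here, and "the series" means these few. Any claim that something is new, unique, unknown or untested is made for them only; others in the source may bear on it.

Compound 1 `OC[C@H]1O[C@@H](n2cnc3c(NCc4ccccc4Br)ncnc32)[C@H](O)[C@@H]1O`: 10000 nM
Compound 2 `COc1cccc(CNc2ncnc3c2ncn3[C@@H]2O[C@H](CO)[C@@H](O)[C@H]2O)c1`: > 166000 nM, a limit of the assay rather than a number
Compound 3 `OC[C@H]1O[C@@H](n2cnc3c(NCc4ccc(Cl)c(Cl)c4)ncnc32)[C@H](O)[C@@H]1O`: 10800 nM

In a functional assay on K562 cells (Homo sapiens) for antiproliferative activity, with a stated time of 72 h (on this read-out lower numbers stand for stronger inhibition and higher numbers for weaker inhibition), compound 3 gives 10800 nM, indistinguishable from compound 1 within the scatter. Compound 4 `Cc1ccc(O)c(CNc2ncnc3c2ncn3[C@@H]2O[C@H](CO)[C@@H](O)[C@H]2O)c1` changes one place: 2-hydroxy-5-methylphenyl in place of 3,4-dichlorophenyl on a saturated chain carbon bound to a nitrogen on an aromatic ring. Of the measured steps, a 1.1-fold higher number from compound 1 to compound 3 (0.03 log units; within the scatter) stayed within the scatter, whereas an at least 16-fold higher number from compound 1 to compound 2 (1.22 log units; beyond the scatter) and an at least 15-fold lower number from compound 2 to compound 3 (1.18 log units; beyond the scatter) were large, the weaker side each time carrying the oxygen-bearing ring. A weakening step a 3.7-fold higher number from compound 3 to compound 4 (0.57 log units; beyond the scatter) is expected because the step of an at least 15-fold lower number from compound 2 to compound 3 (1.18 log units; beyond the scatter) was large. Compound 4 is therefore estimated at 40000 nM, between 9000 nM and 170000 nM.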

Compound 4, half-maximal inhibitory concentration: 16500 nM
For compound 4 the middle estimate is 2.4-fold (0.38 log units) above the measured one, and the stated range covers the measured number.
By their numbers in this assay, from the lowest: compounds 1, 3 and 4 (each within the scatter of the next). At a limit, above all of these: compound 2.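

In this assay, the step of a 1.5-fold higher number from compound 3 to compound 4 (0.18 log units; within the scatter) lies within the scatter, as does a 1.7-fold higher number from compound 1 to compound 4 (0.22 log units; within the scatter), so on this saturated chain carbon a ring without chlorine or bromine matches the halogen-bearing rings. An oxygen on the ring therefore does not always go with weakness: compound 2, with its 3-methoxyphenyl, remains the exception, with an at least 10-fold lower number from compound 2 to compound 4 (1.00 log units; beyond the scatter). The entry for compound 2 is a limit, not a number: the limit of > 166000 nM in this assay, at which 1 of the 4 values shown sits.

The compounds shown leave open whether the hydroxyl or the methyl of compound 4 separates it from compound 2. Going by these compounds, how a ring bearing an amine or a carboxylic acid behaves here also stays open.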